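This account rests on a few compounds, and the source may have more. Where it says the series, first, only, none or still open, it means among the compounds named here.

Going by the values given here, compound 1, with the structure `Cc1cc(O)c(C(=O)/C=C/c2ccc(OCc3ccccc3)cc2)c(-c2ccccc2)c1C(=O)/C=C/c1ccc(OCc2ccccc2)cc1`, is the one compound in this set that has a number in a functional assay on MDA-MB-231 cells (Homo sapiens) for cytotoxicity, read by MTT assay, with a stated time of 24 h; a lower number here means a stronger inhibitor, a higher number a weaker inhibitor: in this assay compound 1 gives 10000 nM. A second compound, compound 2 `COc1ccc(/C=C/C(=O)c2c(C)cc(O)c(C(=O)/C=C/c3ccc(OC)c(OC)c3)c2-c2ccccc2)cc1OC`, differs from compound 1 in several places at once, and in this assay compound 2 is reported as "not active" (no number reported), so no number is available for it. Compound 1 therefore stands alone as the reference point.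

Compound 3 `Cc1cc(O)c(C(=O)/C=C/c2ccc(OCc3ccccc3)cc2)c(-c2ccc(Br)cc2)c1C(=O)/C=C/c1ccc(OCc2ccccc2)cc1` is the next compound to be tested. It differs from compound 1 in one place only: bromo in place of hydrogen on an aromatic carbon, para to a large group. The shared core and all other arms stay the same.

Among the compounds with values here, no pair of measured compounds differs in a single place, so there is no step to lean on. The change is small and adds no hydrogen-bond donor or acceptor, so the expected step from compound 1 to compound 3 in this assay is a 1.3-fold lower number from compound 1 to compound 3 (0.10 log units; within the scatter), within the usual scatter. Compound 3 is expected to give 8000 nM in this assay, estimated to lie between 3000 nM and 25000 nM.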

Compound 3, half-maximal inhibitory concentration: 20000 nM
Estimate against measurement, compound 3: 2.5-fold (0.40 log units) below, and the stated range covers the measured number.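

In this assay the swap of phenyl to 4-bromophenyl gives a 2.0-fold higher number from compound 1 to compound 3 (0.30 log units; within the scatter) and so lies within the usual scatter of repeated measurements, which means compound 1 and compound 3 cannot be told apart here. Going by these compounds alone, this is the first direct reading of this position: a bromo on an aromatic carbon, para to a large group, leaves the read-out indistinguishable from that of the parent with hydrogen in its place, although this conclusion rests on a single pair and a single substituent. Nothing measured on these compounds offers an explanation for this result.

What the compounds shown leave open is whether any group at this place can move the number beyond the scatter, for instance an amine, a carboxylic acid or a longer chain in place of the bromo. Also open, on these data alone, is how much the two large arms of the shared core matter, since compound 2 changes several places at once and carries no number to compare.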